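The compounds below may be only part of what the source reports. "The series", "measured", "known", "first", "only" and "open" are said of these compounds alone.

Compound 1 `O=C(Nc1ccc(OC(=O)c2ccccc2)cc1)Nc1ccc(Cl)c(C(F)(F)F)c1` and compound 2 `O=C(Nc1ccc(Cl)cc1)Nc1ccc(OC(=O)c2ccccc2)cc1` share one core and differ only in a trifluoromethyl group. In a functional assay on A549 cells (Homo sapiens) for antiproliferative activity, read by MTT assay, with a stated time of 48 h (on this read-out lower numbers stand for stronger inhibition and higher numbers for weaker inhibition), compound 1 gives 30100 nM and compound 2 gives 24700 nM; compound 2 stands nearest to compound 1, and the step of a 1.2-fold lower number from compound 1 to compound 2 (0.09 log units; within the scatter) lies within the scatter. Compound 3 `Cc1ccc(NC(=O)Nc2ccc(OC(=O)c3ccccc3)cc2)cc1` differs from compound 2 by methyl in place of chloro on an aromatic carbon. Going by the values given here, no measured step swaps these two groups, so the expectation rests on the single small step already seen. Compound 3 is therefore expected to show a step of a 1.0-fold higher number from compound 2 to compound 3 (0.01 log units; within the scatter), nothing beyond the scatter. The estimate for compound 3 is 25000 nM, with a range from 12000 nM to 55000 nM.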

Compound 3, half-maximal inhibitory concentration: 47700 nM
Compound 3: middle estimate off by 1.9-fold (0.28 log units), on the low side, and the stated range covers the measured number.
By their numbers in this assay, from the lowest: compounds 2, 1 and 3 (each within the scatter of the next).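

Going by these compounds alone, this is the first change to the group para to a large group, and replacing chloro with methyl gives a 1.9-fold higher number from compound 2 to compound 3 (0.29 log units; within the scatter) in this assay. So, in this assay, the compounds shown give no firm sign that chloro and methyl differ at this position on the aromatic ring. Nothing available offers a reason for this step.

From the compounds shown here alone, it remains open whether an amine, a carboxylic acid or a longer alkyl chain here would shift the number beyond the scatter. Hydrogen at this position also remains untested among these compounds.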